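Removing the sulfonyl group from an indole measured for topoisomerase inhibition

The compounds below may be only part of what the source reports. "The series", "measured", "known", "first", "only" and "open" are said of these compounds alone.

Measured compounds:
compound 1 `C[C@@H]1O[C@@H](OCC#Cc2c(-c3ccccc3)[nH]c3ccccc23)C[C@H](N)[C@@H]1O`: 8.8%
compound 2 `Cc1ccc(S(=O)(=O)n2c(-c3ccccc3)c(C#CCO[C@H]3C[C@H](N)[C@@H](O)[C@H](C)O3)c3ccccc32)cc1`: 92.8%

In an assay on isolated protein for inhibition of DNA topoisomerase 1 (Homo sapiens), with a stated time of 30 min, tested at 100 uM (on this read-out lower numbers stand for less inhibition and higher numbers for more inhibition at the one concentration tested (going by the name of the read-out)), compound 2 gives 92.8%, the higher of the two measured numbers, while compound 1 gives 8.8%, a gap well beyond the usual scatter. Compound 3 `C[C@@H]1O[C@@H](OCC#Cc2c(-c3ccccc3)[nH]c3ccccc23)C[C@H](N)[C@H]1O` has not been measured yet. It differs from compound 2 in one place: hydrogen in place of (4-methylphenyl)sulfonyl on an aromatic nitrogen. For the measured compounds named here, no step between two measured compounds is known, so the size of this change can only be estimated. Compound 3 is expected to lose most of the inhibition, a step of a number 77.8 percentage points lower from compound 2 to compound 3 (beyond the scatter), because compound 1, which also carries a hydrogen on an aromatic nitrogen, gives 8.8%. The estimate for compound 3 is 15%, within 0% to 45%.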

Compound 3, a percentage reported as inhibition, at one concentration (the size of the read-out at that concentration, not a potency): 8.2%
Compound 3: the middle estimate sits 6.8 percentage points above what was measured; measured number inside the range.
By their numbers in this assay, from the lowest: compounds 3 and 1 (each within the scatter of the next); then compound 2.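

In this assay, hydrogen in place of (4-methylphenyl)sulfonyl on the aromatic nitrogen now gives a directly measured step, a number 84.6 percentage points lower from compound 2 to compound 3 (beyond the scatter). Without that group, the configuration at the saturated ring carbon makes no readable difference, a number 0.6 percentage points lower from compound 1 to compound 3 (within the scatter). The comparison of this pair rests on one fact: the fact that compounds 1 and 3 differ only in the configuration as drawn

The compounds shown leave open whether inhibition needs the whole (4-methylphenyl)sulfonyl group or only some substituent on that nitrogen, which a methyl or an acetyl there would help to test. They also leave open whether that stereocentre matters when the sulfonyl group is present.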